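Naphthol series: fluoro for hydroxymethyl at the pendant ring

The compounds below may be only part of what the source reports. "The series", "measured", "known", "first", "only" and "open" are said of these compounds alone.

Measured compounds:
compound 1, `Oc1cccc2cc(-c3ccccc3)ccc12`, 20%
compound 2, `OCc1ccc(-c2ccc3c(O)cccc3c2)cc1`, 31%

In an assay for binding affinity to 17-beta-hydroxysteroid dehydrogenase type 2 (Homo sapiens), with a stated time of 20 min, tested at 1 uM (a higher number here means more inhibition at the concentration tested (going by the name of the read-out), a lower number less inhibition), compound 2 stands highest of the two numbers; compound 1 is its nearest neighbour, a number 11 percentage points higher from compound 1 to compound 2 (beyond the scatter). Compound 3, `Oc1cccc2cc(-c3ccc(F)cc3)ccc12`, is not yet measured. It differs from compound 2 by fluoro in place of hydroxymethyl on an aromatic carbon. Going by the values given here, the only measured step that bears on this change is the one from compound 1 to compound 2, a number 11 percentage points higher from compound 1 to compound 2 (beyond the scatter), which put the hydroxymethyl in; compound 3 takes it away again and puts a fluoro in its place. A fluoro carries none of the donor or acceptor count that left with the hydroxymethyl, so compound 3 is expected to sit nearer compound 1 than compound 2. The estimated step is a number 9 percentage points lower from compound 2 to compound 3 (within the scatter). Compound 3 is expected to give 22%, within the range 8% to 38%.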

Compound 3, a percentage reported as inhibition, at one concentration (the size of the read-out at that concentration, not a potency): < 10%
Compound 3 ended at the assay's limit (the forecaster's own chance of this, stated with the estimate: 5%); middle value at least 12 percentage points away from the limit.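

The reading for compound 3 in this assay is a limit of the assay and not a number: the limit of < 10% in this assay, at which 1 of the 3 values shown sits.

Even so, the change at this place, para to a large group, gives a number at least 21 percentage points lower from compound 2 to compound 3 (beyond the scatter), so the read-out does not merely follow whether hydrogen is replaced: hydroxymethyl there gave a gain over hydrogen, and fluoro gives none. The comparison with hydrogen itself is weaker, at a number at least 10 percentage points lower from compound 1 to compound 3 (that floor lies within the scatter), so fluoro cannot be firmly called a loss against hydrogen.

Open, on these data alone, is whether the gain with hydroxymethyl needs its hydroxyl, which a methyl or a methoxy at the same place would test. Also open, as far as these compounds go, is whether an aminomethyl, a carboxylic acid or a longer chain such as hydroxyethyl would read higher than compound 2.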